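Chain extension from compound 1 to compound 3

The source may report more compounds than this note shows. Statements on the series, on what has been measured and on what is new or still open speak of the compounds shown alone.

Measured so far:
compound 1 `N#CNC(=N)NCCCCCn1nc(-c2ccccc2)ccc1=O` gives 31%
compound 2 `CC/N=C(/NC#N)NCCCn1nc(C)ccc1=O` gives 34.5%

Both numbers come from a functional assay on the whole organism with Rattus norvegicus as the target, at a dose of 100 mg/kg; a higher number here means more inhibition at the dose given (going by the name of the read-out), a lower number less inhibition. The values of compound 1 and compound 2 lie within the usual scatter of each other, so no order between them can be read; compound 1 simply stands at the lower of the two numbers. Compound 3 `N#CNC(=N)NCCCCCCn1nc(-c2ccccc2)ccc1=O` differs from compound 1 by a group of 7 heavy atoms (3 carbon, 4 nitrogen; no ring) in place of a group of 6 heavy atoms (2 carbon, 4 nitrogen; no ring), on a saturated chain carbon, five bonds along the chain from an aromatic nitrogen. Among the compounds with values here, no measured pair shows the effect of such a change, so the step in this assay is expected to be none beyond the scatter. For compound 3 the inhibition in this assay is estimated at 32%, ranging from 15% to 50%. The expected step of a number 1 percentage points higher from compound 1 to compound 3 (within the scatter) is accordingly small.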

Compound 3, a percentage reported as inhibition, in the whole organism at one dose (the size of the read-out at that dose, not a potency): 20.5%
Compound 3: the middle estimate sits 11.5 percentage points above what was measured; the range from low to high includes it.
By their numbers in this assay, from the lowest: compound 3; then compounds 1 and 2 (each within the scatter of the next).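

At this saturated chain carbon, five bonds along the chain from an aromatic nitrogen, the series now has its first measured step: in this assay, the group of 7 heavy atoms in place of the group of 6 heavy atoms gives a number 10.5 percentage points lower from compound 1 to compound 3 (beyond the scatter) with no other change to the structure. This single added chain carbon is therefore enough to shift the read-out modestly beyond the scatter. Nothing available speaks to the origin of this step.

On these data alone, whether a longer chain or an amine at this saturated chain carbon would follow the same direction stays open. One step defines no trend along the chain.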